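The source may report more compounds than this note shows. Statements on the series, on what has been measured and on what is new or still open speak of the compounds shown alone.

Values in a functional assay on CCRF-CEM cells (Homo sapiens) for inhibition (a lower number here means a stronger inhibitor, a higher number a weaker inhibitor), so far:

compound 1 `O=C1/C(=C/c2cccc(Cl)c2)Cc2ccccc21` 31800 nM
compound 2 `O=C1/C(=C/c2ccc(Cl)cc2)Cc2ccccc21` 284000 nM
compound 3 `O=C1/C(=C/c2cccc(Br)c2)Cc2ccccc21` 32400 nM

Compound 3 lies within the scatter of compound 1, and both show lower numbers than compound 2. The next change leads to compound 4 `Cc1cccc(/C=C2\Cc3ccccc3C2=O)c1` and brings methyl in place of bromo on an aromatic carbon as methyl in place of bromo on an aromatic carbon, meta to a large group. Within the data shown here, the only measured step that bears on it is a 1.0-fold higher number from compound 1 to compound 3 (0.01 log units; within the scatter) and involves one halogen replacing another. Among the measured compounds shown here, no measured compound carries methyl, so the transfer is uncertain. No step beyond the scatter is expected in this assay for this change. The estimated step is a 1.1-fold higher number from compound 3 to compound 4 (0.03 log units; within the scatter) and it points nowhere firmly. Compound 4 is expected at 35000 nM (range 15000 nM to 80000 nM).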

Compound 4, half-maximal inhibitory concentration: 41300 nM
For compound 4 the middle estimate is 1.2-fold (0.07 log units) below the measured one, within the range that was stated.
By their numbers in this assay, from the lowest: compounds 1, 3 and 4 (each within the scatter of the next); then compound 2.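

In this assay, methyl at this place, meta to a large group, reads level with both halogens, whether it replaces bromo (a 1.3-fold higher number from compound 3 to compound 4 (0.11 log units; within the scatter)) or chloro (a 1.3-fold higher number from compound 1 to compound 4 (0.11 log units; within the scatter)). The earlier compounds shown here showed only one halogen exchanged for another, whereas these steps extend the flat reading to a group that is not a halogen, so chloro, bromo and methyl are not separated here. Nothing available bears on why these three groups read alike. Still open, going by these compounds, is whether an amine, a carboxylic acid or a longer chain at this place would also leave the number within the scatter.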